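The source may hold more compounds than are shown below. What is called first, only, known or untested is meant among the compounds shown, and "the series" means these compounds.

Among the measured compounds shown here, compound 1, `Cc1noc(C)c1S(=O)(=O)N1CCC(N2CCC(C)CC2)CC1`, is one of only two compounds so far measured in an ADME assay on HCT-116 cells (Homo sapiens) for cytotoxicity, read by CellTiter-Glo, with a stated time of 72 h; on this read-out higher numbers stand for weaker inhibition and lower numbers for stronger inhibition. In this assay compound 1 gives > 10000 nM, which is a limit of the assay and not a number. The second compound, compound 2, `CC1CCN(C2CCN(S(=O)(=O)c3cccc4ccccc34)CC2)CC1`, has been measured in the same way. In this assay compound 2 gives > 10000 nM, again a limit rather than a number. Compound 1 therefore stands exactly where every value shown stands: the limit of > 10000 nM in this assay, at which 2 of the 2 values shown sit. For the measured compounds named here, no pair of measured compounds differs in a single place, so no measured step is available. Compound 3, `CC1CCN(C2CCN(S(=O)(=O)c3cccnc3F)CC2)CC1`, still awaits measurement in this assay. It differs from compound 1 in one place: 2-fluoropyridin-3-yl in place of 3,5-dimethyl-1,2-oxazol-4-yl on a sulfonyl sulfur. With both known values sitting at the limit, the expectation for this change is a step of no size beyond the scatter, in no particular direction. Compound 3 is therefore estimated to give 15000 nM, expected to lie between 5000 nM and 50000 nM. The expected step is a step that the limit leaves unreadable from compound 1 to compound 3.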

Compound 3, half-maximal inhibitory concentration: > 10000 nM
Compound 3: no number, only a limit; the forecaster's own chance of this, stated with the estimate: 80%; the middle value does not contradict the limit.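

Among the compounds shown here, compound 3 gives > 10000 nM in this assay, a limit of the assay and not a number, and compound 1 also has only a limit, so no step from compound 1 to compound 3 can be read. All the compounds stand together: the limit of > 10000 nM in this assay, at which 3 of the 3 values shown sit. The compounds shown leave open what number any of them would give, and whether 2-fluoropyridin-3-yl and 3,5-dimethyl-1,2-oxazol-4-yl differ at all in this assay.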